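Cinnamyl hydroxamate on the shared core of compound 3

The source may report more compounds than this note shows. Statements on the series, on what has been measured and on what is new or still open speak of the compounds shown alone.

Compound 3 `O=C(NO)c1cccc(-c2cn([C@@H]3C[C@H](CO)N(CCCc4ccccc4)C3)nn2)c1` returns only a limit in an assay on Sf9 cells for inhibition of histone deacetylase 11 (Homo sapiens), read by fluorescence, tested at 0.5 uM; a lower number here means less inhibition, a higher number more inhibition at the concentration tested (going by the name of the read-out): its value of < 10% is a limit of the assay, not a number, and (the limit of < 10% in this assay, at which 1 of the 3 values shown sits). Its closest measured neighbour, compound 2 `O=C(NO)c1ccc(-c2cn([C@@H]3C[C@H](CO)N(CCCc4ccccc4)C3)nn2)cc1`, gives 15% in this assay; the step of a number at least 5 percentage points lower from compound 2 to compound 3 (that floor lies within the scatter). Compound 1 `O=C(/C=C/c1cn([C@H]2C[C@@H](CO)N(CCCc3ccccc3)C2)nn1)NO` gives 31% in this assay and carries the 2-(hydroxycarbamoyl)ethenyl group on a core of the other configuration.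

Compound 4 `O=C(/C=C/c1cn([C@@H]2C[C@H](CO)N(CCCc3ccccc3)C2)nn1)NO` is not yet measured. The change 2-(hydroxycarbamoyl)ethenyl in place of 3-(hydroxycarbamoyl)phenyl on an aromatic carbon replaces the aryl hydroxamate with the open-chain one. Within the data shown here, no measured step follows this change on the core of compound 3; the only measured step, between compound 2 and compound 3, concerns the position of the hydroxycarbamoyl group on the phenyl ring and lies within the scatter. Among the measured compounds shown here, the step of a number at least 10 percentage points higher from compound 3 to compound 4 (that floor lies within the scatter) is estimated as a rise, with compound 1 31% as the only compound bearing the entering group. Compound 4 is expected to give 20% in this assay, between 5% and 40%.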

Compound 4, a percentage reported as inhibition, at one concentration (the size of the read-out at that concentration, not a potency): 12%
Compound 4: middle estimate off by 8 percentage points, on the high side; measured number inside the range.
By their numbers in this assay, from the lowest: compounds 4 and 2 (each within the scatter of the next); then compound 1. At a limit, below all of these: compound 3.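

In this assay, the 2-(hydroxycarbamoyl)ethenyl group does not read the same on both configurations of the shared core, with a number 19 percentage points lower from compound 1 to compound 4 (beyond the scatter), a gap that can be set on configuration alone: the fact that compounds 1 and 4 differ only in the configuration as drawn

On the core of compound 4, the open-chain group shows no separation from the 4-(hydroxycarbamoyl)phenyl group, with a number 3 percentage points lower from compound 2 to compound 4 (within the scatter).

Compound 3 remains at < 10%, a limit of the assay and not a number, and the step to the open-chain group reads only as a number at least 2 percentage points higher from compound 3 to compound 4 (that floor lies within the scatter).

Still open, on these data alone, is whether a configuration gap of this kind also appears with the 4-(hydroxycarbamoyl)phenyl group on the core of compound 1. Also open, as far as these compounds go, is how a carboxylic acid in place of the hydroxycarbamoyl group would read in this assay.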